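Swapping a Branched Alkenyl Amine for a Phenylethyl Amine

This account rests on a few compounds, and the source may have more. Where it says the series, first, only, none or still open, it means among the compounds named here.

Of the compounds shown here, three built on one shared core have been measured in an assay on CHO cells for agonist activity at 5-hydroxytryptamine receptor 1D (Homo sapiens), read by GTPgammaS binding; a higher number here means that more compound is needed for the effect, a lower number that less compound is needed. Compound 1 `CN(Cc1cccs1)C1CCN(CCCc2c[nH]c3ccc(-n4cnnc4)cc23)CC1` gives 3.5 nM. Compound 2 `NC(=O)OC[C@H](NC1CCN(CCCc2c[nH]c3ccc(-n4cnnc4)cc23)CC1)c1ccccc1` gives 9.3 nM. Compound 3 `CC(C)=CCN(C)C1CCN(CCCc2c[nH]c3ccc(-n4cnnc4)cc23)CC1` gives 1.8 nM. Among the measured compounds shown here, the single one-point step among them, a 1.9-fold lower number from compound 1 to compound 3 (0.29 log units; within the scatter), shows that exchanging the group on the chain bound to the amine nitrogen barely moves the number. Compound 3 thus sits alongside compound 1, while compound 2, also a secondary amine bearing a phenyl group, shows a clearly higher number than compound 3. Compound 4 `C[C@H](NC1CCN(CCCc2c[nH]c3ccc(-n4cnnc4)cc23)CC1)c1ccccc1` arises from compound 3 by (1-phenylethyl)amino in place of methyl(3-methylbut-2-en-1-yl)amino on a saturated ring carbon. For the measured compounds named here, no measured step covers this exact change; the step from compound 1 to compound 3 bears on it only by suggesting that changes at this amine tend to stay small, whereas compound 2 hints that a secondary amine with a phenyl group may carry a somewhat higher number. Compound 4 is therefore expected to land between those two readings, at 5 nM, with a range of 1.5 nM to 15 nM. The expected step of a 2.8-fold higher number from compound 3 to compound 4 (0.44 log units; beyond the scatter) is a modest rise, at the edge of the scatter.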

Compound 4, half-maximal effective concentration: 12 nM
Compound 4: middle estimate off by 2.4-fold (0.38 log units), on the low side; the measured number falls inside the stated range.
By their numbers in this assay, from the lowest: compounds 3 and 1 (each within the scatter of the next); then compounds 2 and 4 (each within the scatter of the next).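

In this assay, the amine on the saturated ring carbon proves less forgiving than compound 1 and compound 3 alone suggested: (1-phenylethyl)amino brings a modest rise in place of methyl(3-methylbut-2-en-1-yl)amino (a 6.7-fold higher number from compound 3 to compound 4 (0.82 log units; beyond the scatter)) and in place of methyl((thiophen-2-yl)methyl)amino (a 3.4-fold higher number from compound 1 to compound 4 (0.54 log units; beyond the scatter)). Hydrogen in place of carbamoyloxy on the chain of this amine, by contrast, leaves the number within the scatter (a 1.3-fold higher number from compound 2 to compound 4 (0.11 log units; within the scatter)), so compound 2 and compound 4 read alike. Nothing measured here explains the rise.

The entering group differs from the leaving ones both in its amine hydrogen and in its phenyl ring, and these compounds cannot separate the two. A methyl(1-phenylethyl)amino group would test the first, while the opposite configuration at the stereocentre remains a further open question.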